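The source may report more compounds than this note shows. Statements on the series, on what has been measured and on what is new or still open speak of the compounds shown alone.

Series notes. The compounds share one core and differ only in the group on a saturated chain carbon bound to a saturated ring carbon. Compound 1 `CCN1CCN(C[C@H]2CN(c3ccc(-n4cc(-c5ccccn5)cn4)c(F)c3)C(=O)O2)CC1` carries 4-ethylpiperazin-1-yl there, and in an ADME assay on L02 cells (Homo sapiens) for cytotoxicity, read by MTT assay, with a stated time of 48 h (on this read-out lower numbers stand for stronger inhibition and higher numbers for weaker inhibition), compound 1 gives 99 ug/mL. Compound 3 `O=C1O[C@@H](Cn2ccnc2)CN1c1ccc(-n2cc(-c3ccccn3)cn2)c(F)c1` carries 1H-imidazol-1-yl, and in this assay compound 3 gives 350 ug/mL. Compound 2 `O=C1O[C@@H](CN2CCCCC2)CN1c1ccc(-n2cc(-c3ccccn3)cn2)c(F)c1` carries piperidin-1-yl. In this assay compound 2 gives only a limit of the assay, > 400 ug/mL, so its position is known as a floor only (the limit of > 400 ug/mL in this assay, at which 1 of the 3 values shown sits). The step of an at least 4.0-fold higher number from compound 1 to compound 2 (0.60 log units; beyond the scatter) and the step of a 3.5-fold higher number from compound 1 to compound 3 (0.55 log units; beyond the scatter) are both beyond the scatter, whereas an at least 1.1-fold lower number from compound 2 to compound 3 (0.05 log units; that floor lies within the scatter) is not; every compound apart from compound 1 reads high in this assay.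

Compound 4 `CCC(=O)NC[C@H]1CN(c2ccc(-n3cc(-c4ccccn4)cn3)c(F)c2)C(=O)O1` is not yet measured. Against compound 2 the change is propanoylamino in place of piperidin-1-yl on a saturated chain carbon bound to a saturated ring carbon. Among the measured compounds shown here, no measured step exchanges a ring group for an acyclic amide at this position, so the change cannot be sized from the steps seen. Given that compound 2 sits at the limit and compound 3 also reads high, the step of a number no higher from compound 2 to compound 4 (the limit leaves the size open) is expected to stay within the scatter. Compound 4 is expected to give about 400 ug/mL in this assay, with a range from 200 ug/mL to 800 ug/mL, and a fair chance that only a limit is reported.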

Compound 4, half-maximal inhibitory concentration: 204 ug/mL
Compound 4: the middle estimate sits 2.0-fold (0.29 log units) above what was measured, within the range that was stated.
By their numbers in this assay, from the lowest: compound 1; then compounds 4 and 3 (each within the scatter of the next). At a limit, above all of these: compound 2.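

Propanoylamino puts the first group without a ring at this position, and a 1.7-fold lower number from compound 3 to compound 4 (0.23 log units; within the scatter) leaves it level with 1H-imidazol-1-yl in this assay, so a ring on this chain carbon is not required for a high reading. Among the compounds shown here, with a 2.1-fold higher number from compound 1 to compound 4 (0.31 log units; beyond the scatter) added to the earlier steps, 4-ethylpiperazin-1-yl remains the only group of the four that reads apart at the low end, though this new gap is modest. The step of an at least 1.9-fold lower number from compound 2 to compound 4 (0.29 log units; that floor lies within the scatter) cannot be sized further, and compound 2 remains a limit of the assay: the limit of > 400 ug/mL in this assay, at which 1 of the 4 values shown sits.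

As far as these compounds go, whether the low reading of compound 1 belongs to the piperazine ring or to its ethyl group stays open, and piperazin-1-yl without the ethyl would separate the two. Also open, from the compounds shown here alone, is how a primary amine, a carboxylic acid or a longer acyl chain would read at this position.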